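The compounds below may be only part of what the source reports. "The series", "measured", "known", "first", "only" and "open" are said of these compounds alone.

In an in vitro ADME assay on microsomes from liver (Homo sapiens) for metabolic stability (on this read-out lower numbers stand for slow clearance and higher numbers for fast clearance), compound 1 `Nc1cc(Nc2ccc(Oc3ccc(Cl)cc3)cc2)ncn1` gives < 14 mL.min-1.g-1, which is a limit of the assay and not a number. Compound 2 `Nc1nccc(Nc2ccc(Oc3ccc(Cl)cc3)cc2)n1`, with 2-aminopyrimidin-4-yl in place of 6-aminopyrimidin-4-yl, gives 206 mL.min-1.g-1. Compound 3 `Nc1cc(Nc2ccc(Oc3ccc(Cl)cc3)cc2)cnn1` has not yet been measured and differs from compound 1 by 6-aminopyridazin-4-yl in place of 6-aminopyrimidin-4-yl on a nitrogen on an aromatic ring, with the same atoms joined differently. For the measured compounds named here, with an at least 14-fold higher number from compound 1 to compound 2 (1.16 log units; beyond the scatter) as the only measured step that bears on this change, a smaller rise is expected in this assay. The estimated step is an at least 2.1-fold higher number from compound 1 to compound 3 (0.33 log units; beyond the scatter). For compound 3 the expected value is 30 mL.min-1.g-1, with an estimated range from 10 mL.min-1.g-1 to 120 mL.min-1.g-1.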

Compound 3, intrinsic clearance in microsomes: 20 mL.min-1.g-1
For compound 3 the middle estimate is 1.5-fold (0.18 log units) above the measured one; the measured number falls inside the stated range.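

In this assay, the place on a nitrogen on an aromatic ring proves sensitive to how the same atoms are joined, since 6-aminopyridazin-4-yl replacing 2-aminopyrimidin-4-yl gives a 10-fold lower number from compound 2 to compound 3 (1.01 log units; beyond the scatter). Against 6-aminopyrimidin-4-yl, the change gives an at least 1.4-fold higher number from compound 1 to compound 3 (0.15 log units; that floor lies within the scatter), so no rise beyond the scatter can be claimed for compound 3. That step is only a floor, as compound 1 stands at a limit of the assay and not at a number: the limit of < 14 mL.min-1.g-1 in this assay, at which 1 of the 3 values shown sits.

Open, on these data alone, is how a methylamino or hydroxyl group in place of the amino group would read in this assay. A pyridine ring at this place also remains untested by the compounds shown.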